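The compounds below may be only part of what the source reports. "The series", "measured", "known", "first", "only" and "open" are said of these compounds alone.

Measured in an ADME assay on Vero cells (Chlorocebus sabaeus) for cytotoxicity, read by MTT assay, with a stated time of 48 h; on this read-out lower numbers stand for stronger inhibition and higher numbers for weaker inhibition:
Compound 1 `O=C(OC1CCC(CN2CCN(c3cc(=O)c4cc(C(F)(F)F)cc([N+](=O)[O-])c4s3)CC2)CC1)c1cccc(F)c1`: > 64 ug/mL
Compound 2 `COc1cccc(C(=O)OC2CCC(CN3CCN(c4cc(=O)c5cc(C(F)(F)F)cc([N+](=O)[O-])c5s4)CC3)CC2)c1`: > 64 ug/mL
Compound 3 `O=C(OC1CCC(CN2CCN(c3cc(=O)c4cc(C(F)(F)F)cc([N+](=O)[O-])c4s3)CC2)CC1)C1CCCCC1`: > 64 ug/mL

Each of these entries is a limit of the assay and not a number. The three compounds share one reading, (the limit of > 64 ug/mL in this assay, at which 3 of the 3 values shown sit), so compound 3 cannot be placed relative to the other two. The next compound, compound 4 `O=C(OC1CCC(CN2CCN(c3cc(=O)c4cc(C(F)(F)F)cc([N+](=O)[O-])c4s3)CC2)CC1)c1ccc2ccccc2c1`, keeps everything in compound 3 except the group on the ester carbonyl: naphthalen-2-yl in place of cyclohexyl on a carbonyl carbon. In words, naphthalen-2-yl stands in place of cyclohexyl on a carbonyl carbon.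

Among the compounds with values here, two measured steps concern that same carbonyl carbon. Within the data shown here, the first is a step that the two limits leave unreadable from compound 1 to compound 3, and the second is a step that the two limits leave unreadable from compound 2 to compound 3. Neither gives a size or a direction. The nearest guide is therefore compound 2, which has an aromatic ring at this carbon and reads > 64 ug/mL. Compound 1 also has an aromatic ring there and reads > 64 ug/mL. On this basis, no step beyond the scatter is expected in this assay, and compound 4 is expected to be reported as a limit again. The estimated change is a step that the limit leaves unreadable from compound 3 to compound 4. For compound 4 the expected value is 70 ug/mL, with an estimated range from 32 ug/mL to 128 ug/mL.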

Compound 4, half-maximal inhibitory concentration: > 64 ug/mL
Compound 4 was reported as a limit (the forecaster's own chance of this, stated with the estimate: 85%); the middle value does not contradict the limit.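

In this assay compound 4 gives > 64 ug/mL, which is a limit of the assay and not a number. No step from compound 1, compound 2 or compound 3 to compound 4 can be read, since all four compounds share one reading: the limit of > 64 ug/mL in this assay, at which 4 of the 4 values shown sit.

The compounds shown leave open how the four compounds rank against one another in this assay, and whether the group on the carbonyl carbon changes the reading at all.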